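A few compounds are considered here, and "the series" means these few. Any claim that something is new, unique, unknown or untested is made for them only; others in the source may bear on it.

Measured so far in an ADME assay on HepG2 2.2.15 cells (Homo sapiens) for cytotoxicity; a lower number here means that less compound is tolerated, a higher number that more compound is tolerated:
- compound 1, `COC(=O)CCCCNc1ncc(C(Oc2ccc3cc(Br)ccc3c2)c2ccc(Cl)cc2)s1`, gives "not toxic" (no number reported)
- compound 2, `O=C(Nc1ncc(C(Oc2ccc3cc(Br)ccc3c2)c2ccc(Cl)cc2)s1)C1CC1`, gives "not toxic" (no number reported)
- compound 3, `CCCCCC(=O)Nc1ncc(C(Oc2ccc3cc(Br)ccc3c2)c2ccc(Cl)cc2)s1`, gives > 50000 nM

The entry for compound 3 is a limit of this assay, not a number. It sits at the limit of > 50000 nM in this assay, at which 1 of the 3 values shown sits, and the other two entries carry no number at all, so none of the three compounds has a measured half-maximal cytotoxic concentration to stand against another. Among the measured compounds shown here, no pair among compounds 1, 2 and 3 differs in a single place, and no step between measured compounds can be given.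

Compound 4, `CC(C)(C)C(=O)Nc1ncc(C(Oc2ccc3cc(Br)ccc3c2)c2ccc(Cl)cc2)s1`, differs from compound 3 by tert-butyl in place of pentyl on a carbonyl carbon. For the measured compounds named here, with compound 3 only at a limit, and compounds 1 and 2 reported without a number, there is no measured step on which to size the change. The step that the limit leaves unreadable from compound 3 to compound 4 is expected to be none beyond the scatter. Compound 4 is estimated at 80000 nM, with a range from 30000 nM to 300000 nM, most likely again reported only as a limit.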

Compound 4, half-maximal cytotoxic concentration: "not toxic" (no number reported)
For compound 4 the study gives words and no number; the estimate stays without a comparison.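

In this assay compound 4 gives "not toxic" (no number reported). Compound 3 gives > 50000 nM, which is a limit and not a number. Among the compounds shown here, no step from compound 3 to compound 4 can be read. Going by these compounds, whether tert-butyl in place of pentyl shifts the half-maximal cytotoxic concentration at all stays open.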